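Series notes: aryl swap on the shared core, compound 3

The source may report more compounds than this note shows. Statements on the series, on what has been measured and on what is new or still open speak of the compounds shown alone.

Measured so far in a functional assay on HCT-116 cells (Homo sapiens) for inhibition, read by MTT assay, with a stated time of 24 h, tested at 2.5 uM; on this read-out lower numbers stand for less inhibition of growth and higher numbers for more inhibition of growth at the one concentration tested:
- compound 1 `CS(=O)(=O)c1ccc(-c2cnc3[nH]cc(-c4nnc(-c5ccccn5)o4)c(=O)c3c2)cc1`: 5.37%
- compound 2 `CS(=O)(=O)c1ccc(-c2cnc3[nH]cc(-c4nnc(-c5ccc(Cl)cc5)o4)c(=O)c3c2)cc1`: 2.06%

Compound 2 holds the lowest of the two numbers; the nearest is compound 1, and the step of a number 3.3 percentage points lower from compound 1 to compound 2 (within the scatter) is within the scatter, so the two values give no order between them. Both sit near the bottom of the read-out.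

Compound 3 `O=c1c(-c2nnc(-c3ccc(Cl)cc3)o2)c[nH]c2ncc(-c3cccnc3)cc12` differs from compound 2 in one place: pyridin-3-yl in place of 4-(methylsulfonyl)phenyl on an aromatic carbon. Among the compounds with values here, the only measured step, from compound 1 to compound 2, changes a different group and says nothing about this position. Within the data shown here, no measured pair bears on the present change. With both measured values low and no step beyond the scatter anywhere in the series, the expectation for compound 3 is a number close to that of compound 2, with an estimated step of a number 1.9 percentage points higher from compound 2 to compound 3 (within the scatter), that is, none beyond the scatter. The estimated value for compound 3 in this assay is 4%, with a range from -5% to 13%.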

Compound 3, percent growth inhibition at one concentration: 10.4%
Estimate against measurement, compound 3: 6.4 percentage points below; the range from low to high includes it.
By their numbers in this assay, from the lowest: compounds 2, 1 and 3 (each within the scatter of the next).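

In this assay, within the data shown here, this is the first reading at the position on the aromatic carbon para to a fused ring, since the earlier step changed only the aryl group at the other end of the shared core. Replacing 4-(methylsulfonyl)phenyl with pyridin-3-yl removes the sulfur and both oxygens, brings in a ring nitrogen and reduces the group from 10 heavy atoms to 6, yet the result is a number 8.3 percentage points higher from compound 2 to compound 3 (within the scatter), so this exchange does not separate the two compounds on this read-out. The data offer no measured basis for explaining this result.

Two aromatic groups at this position cannot show how far the read-out tolerates change there, and a morpholine, a carboxylic acid or a longer alkyl chain on the same carbon would test a different kind of substituent from either aromatic ring. From the compounds shown here alone, it also remains open whether pyridin-3-yl would give a similar reading with pyridin-2-yl in place of the 4-chlorophenyl group, and whether any of these changes would move the number beyond the usual scatter.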